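Moving the Chlorine Around the Aryl Ring

The source may hold more compounds than are shown below. What is called first, only, known or untested is meant among the compounds shown, and "the series" means these compounds.

Measured compounds:
Compound 1, `Oc1cc(C(F)(F)F)ccc1-c1nc(-c2ccccc2O)n(-c2ccc(I)cc2)n1`, gives 70.1% in a functional assay on PC-12 cells (Rattus norvegicus) for cytotoxicity, read by MTT assay, with stated times of 2 h and 24 h, tested at 1 uM; on this read-out higher numbers stand for a stronger effect at the one concentration tested and lower numbers for a weaker effect.
Compound 2, `Oc1cc(C(F)(F)F)ccc1-c1nc(-c2ccccc2O)n(-c2ccccc2Cl)n1`, gives 70.1% in this assay.

Compound 2 stands level with compound 1 at the digits shown; the only measured step, no change at the digits printed from compound 1 to compound 2 (within the scatter), is within the scatter. Within the data shown here, that step swaps one aryl group for another on the same aromatic nitrogen, so it is the one piece of evidence on how this part of the molecule matters to this assay, and it suggests the read-out is not sensitive to what sits there.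

Compound 3, `Oc1cc(C(F)(F)F)ccc1-c1nc(-c2ccccc2O)n(-c2cccc(Cl)c2)n1`, differs from compound 2 by 3-chlorophenyl in place of 2-chlorophenyl on an aromatic nitrogen. Among the measured compounds shown here, no measured pair shows exactly this change, but the swap of aryl groups from compound 1 to compound 2 is the nearest comparison and was flat. The expectation is therefore a step no larger than the scatter, a number 2.1 percentage points lower from compound 2 to compound 3 (within the scatter), in either direction. For compound 3 the estimated value in this assay is 68%, with a range from 50% to 85%.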

Compound 3, a percentage reported as activity, at one concentration (the size of the read-out at that concentration, not a potency): 72.3%
The estimate for compound 3 lay 4.3 percentage points below the measured number; the range from low to high includes it.
By their numbers in this assay, from the lowest: compounds 1, 2 and 3 (each within the scatter of the next).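

Moving the chlorine so that 3-chlorophenyl replaces 2-chlorophenyl keeps the same atoms and only joins them differently, and in this assay this gives a number 2.2 percentage points higher from compound 2 to compound 3 (within the scatter). The exchange of the 4-iodophenyl group reads much the same, with a number 2.2 percentage points higher from compound 1 to compound 3 (within the scatter), so all three aryl groups on this aromatic nitrogen now lie within the scatter of one another, and the place of the chlorine on the ring, not just the choice of aryl group, makes no difference that this read-out can separate. Nothing available here offers an explanation for this flat result.

All three compounds carry a single halogen on a phenyl ring at this nitrogen, and each reading comes from one concentration, so it reflects the size of the effect at that concentration and says nothing about potency. As far as these compounds go, whether the picture stays as flat with an amine or a carboxylic acid on that phenyl ring, or with a simple alkyl chain in place of the ring, remains open.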